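This account rests on a few compounds, and the source may have more. Where it says the series, first, only, none or still open, it means among the compounds named here.

Measured compounds in a functional assay on MCF7 cells (Homo sapiens) for antiproliferative activity, read by MTT assay, with a stated time of 72 h; on this read-out higher numbers stand for weaker inhibition and lower numbers for stronger inhibition:
- compound 1 `Clc1ccc(-c2csc(N3N=C(c4ccc(N5CCCCC5)cc4)CC3c3ccc(Cl)cc3)n2)cc1`: compound 1 gives > 100000 nM, a limit of the assay.
- compound 2 `FC(F)(F)c1ccc(-c2csc(N3N=C(c4ccc(N5CCCCC5)cc4)CC3c3ccc(Cl)cc3)n2)cc1`: compound 2 gives 23700 nM.
- compound 3 `COc1ccc(-c2csc(N3N=C(c4ccc(N5CCCCC5)cc4)CC3c3ccc(Cl)cc3)n2)cc1`: compound 3 gives > 100000 nM, a limit of the assay.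

Compound 3 thus stands only at a limit, and it is not alone there (the limit of > 100000 nM in this assay, at which 2 of the 3 values shown sit). Within the data shown here, the one compound with a number is compound 2, so the measured steps that touch compound 3 are an at least 4.2-fold higher number from compound 2 to compound 3 (0.62 log units; beyond the scatter) and a step that the two limits leave unreadable from compound 1 to compound 3; the second tells nothing about size. Among the measured compounds shown here, the only step in the set that moves a value off the limit is an at least 4.2-fold lower number from compound 1 to compound 2 (0.62 log units; beyond the scatter), and it concerns trifluoromethyl, a change of a different kind from the one now made.

Compound 4 `Clc1ccc(C2CC(c3ccc(N4CCCCC4)cc3)=NN2c2nc(-c3ccc4ccccc4c3)cs2)cc1` differs from compound 3 by naphthalen-2-yl in place of 4-methoxyphenyl on an aromatic carbon. For the measured compounds named here, no measured pair swaps a single six-membered ring for a fused pair of rings at that position, so the expectation rests only on how often this series sits at the limit. Compound 4 is estimated at 60000 nM, within 15000 nM to 150000 nM, which would mean an expected step of an at least 1.6-fold lower number from compound 3 to compound 4 (0.22 log units; that floor lies within the scatter), and a reading at the limit remains a real possibility.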

Compound 4, half-maximal inhibitory concentration: > 100000 nM
Compound 4 was reported as a limit (the forecaster's own chance of this, stated with the estimate: 45%); middle value at least 1.6-fold (0.22 log units) from the limit.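

Naphthalen-2-yl, with its two six-membered aromatic rings of carbon only, gives no number at this aromatic carbon in this assay: compound 4 gives > 100000 nM, a limit of the assay. Against the one compound with a number, the change gives an at least 4.2-fold higher number from compound 2 to compound 4 (0.62 log units; beyond the scatter), so a second ring on this position does not reach the value seen with 4-(trifluoromethyl)phenyl. Compound 2 remains the only compound off the limit, and the steps linking compound 4 to compound 1 and compound 3 cannot be read, since both ends of each are limits: the limit of > 100000 nM in this assay, at which 3 of the 4 values shown sit.

Going by these compounds, whether compound 1, compound 3 and compound 4 differ from one another remains open. Also open, on these data alone, is whether a phenyl ring carrying a nitrile, an amine or a carboxylic acid at this position would give a number.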